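The source may hold more compounds than are shown below. What is called first, only, known or untested is meant among the compounds shown, and "the series" means these compounds.

Among the compounds with values here, in a functional assay on HeLa cells (Homo sapiens) for inhibition, read by CCK-8 assay, with a stated time of 72 h, tested at 8 uM (on this read-out higher numbers stand for more inhibition of growth at the one concentration tested and lower numbers for less inhibition of growth), compound 1 (`Nc1ccccc1NC(=O)/C=C/c1ccc(CSc2ccc(Cl)cc2)cc1`) gives 17.3%, the lower of the two numbers so far and well beyond the scatter from compound 2 (`Nc1ccccc1NC(=O)c1ccc(CSCCc2ccccc2)cc1`), which gives 74.8%. Compound 3 (`CC(C)(C)c1ccc(SCc2ccc(/C=C/C(=O)Nc3ccccc3N)cc2)cc1`) has not yet been measured and differs from compound 1 in one place: tert-butyl in place of chloro on an aromatic carbon. Within the data shown here, no measured pair shows what this swap does, so no change beyond the scatter is expected, and the estimated step is small: a number 4.7 percentage points higher from compound 1 to compound 3 (within the scatter). The estimate for compound 3 is 22%, with an expected range from 6% to 45%.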

Compound 3, percent growth inhibition at one concentration: 9.8%
The estimate for compound 3 lay 12.2 percentage points above the measured number; the measured number falls inside the stated range.
By their numbers in this assay, from the lowest: compounds 3 and 1 (each within the scatter of the next); then compound 2.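

In this assay, tert-butyl in place of chloro on the aromatic carbon gives a number 7.5 percentage points lower from compound 1 to compound 3 (within the scatter). This position therefore takes a group of 4 heavy atoms in place of 1 with no change beyond the scatter, and the read-out stays as it was with this 4-(tert-butyl)phenyl end. Nothing available explains this outcome. Still open, as far as these compounds go, is whether a group of another kind at this place, such as an amine or a carboxylic acid, would move the number beyond the scatter.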